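This account rests on a few compounds, and the source may have more. Where it says the series, first, only, none or still open, it means among the compounds named here.

Measured compounds:
compound 1 `N#Cc1ccc(OCC2(O)CCN(S(=O)(=O)c3ccc(Cl)cc3Cl)C2)cc1F` — 150 nM
compound 2 `N#Cc1ccc(OC[C@H]2CN(S(=O)(=O)c3ccc(Cl)cc3Cl)C[C@H]2O)cc1F` — 1500 nM
compound 3 `N#Cc1ccc(OC[C@@]2(O)CN(S(=O)(=O)c3ccc(Cl)cc3Cl)C[C@@H]2O)cc1F` — 150 nM

In an assay on cells for antagonist activity at transient receptor potential cation channel subfamily V member 4 (Homo sapiens), read by FLIPR and calcium flux, with a stated time of 10 min (a lower number here means a stronger inhibitor, a higher number a weaker inhibitor), compound 1 gives 150 nM, and compound 3 gives 150 nM; these two values sit within the scatter of each other. Compound 2 gives 1500 nM and so carries the highest number of the three, a gap to both compound 1 and compound 3 that lies beyond the scatter. Compound 4 `N#Cc1ccc(OC[C@@H]2CN(S(=O)(=O)c3ccc(Cl)cc3Cl)C[C@H]2O)cc1F` has not yet been measured in this assay. Its relation to compound 2 is this: the two compounds have the same atoms and bonds and differ only in configuration as drawn: 1 of 2 stereo elements differ; a stereocentre at a saturated ring carbon is drawn R in compound 2 and S in compound 4. Among the compounds with values here, no measured pair in the set differs only in configuration, so there is no directly comparable step to lean on. The account expects that the change in configuration will move the number, with the more likely direction downward toward the values of compound 1 and compound 3, though a result within the scatter of compound 2 cannot be excluded. The estimated step is a 3.8-fold lower number from compound 2 to compound 4 (0.57 log units; beyond the scatter). For compound 4 the estimate in this assay is 400 nM, with a range from 100 nM to 1600 nM.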

Compound 4, half-maximal inhibitory concentration: 1000 nM
The estimate for compound 4 lay 2.5-fold (0.40 log units) below the measured number; measured number inside the range.
By their numbers in this assay, from the lowest: compounds 1 and 3 (each within the scatter of the next); then compounds 4 and 2 (each within the scatter of the next).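

In this assay, the set now holds its first pair that differs only in configuration, and it gives a 1.5-fold lower number from compound 2 to compound 4 (0.18 log units; within the scatter). Inverting this stereocentre at a saturated ring carbon therefore leaves the number within the scatter, so at this position the configuration as drawn makes no measurable difference, at least with the rest of the structure held fixed. The comparison is a clean one, with no group entering or leaving to confound it: the fact that compounds 2 and 4 differ only in the configuration as drawn

The compounds shown leave open whether the other stereo element, which stays the same in this pair, would matter more if it were inverted. They also leave open how the number would respond if an amine or a methoxy group took the place of the hydroxyl on this scaffold.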